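This account rests on a few compounds, and the source may have more. Where it says the series, first, only, none or still open, it means among the compounds named here.

Measured so far in a functional assay (mast cells) for inhibition, with Rattus norvegicus as the target; a lower number here means that less compound is needed, a higher number that more compound is needed for the effect:
- Compound 1 `Cc1ccc(N/N=C2\CCC(C)n3c2ncc(C(=O)O)c3=O)cc1`: 280 nM
- Compound 2 `CC(=O)c1ccc(N/N=C2\CCC(C)n3c2ncc(C(=O)O)c3=O)cc1`: 8100 nM

Of these two, compound 2 has the higher number, 8100 nM, so more of it is needed for the effect. The next compound, compound 3 `CCCCc1ccc(N/N=C2\CCC(C)n3c2ncc(C(=O)O)c3=O)cc1`, has butyl in place of acetyl on an aromatic carbon. Going by the values given here, only one measured step bears on this position, and it is large: a 29-fold higher number from compound 1 to compound 2 (1.46 log units; beyond the scatter), on putting acetyl in place of methyl. Butyl, like methyl, is a plain carbon chain, so a large move back towards compound 1 seems likely in this assay, to a lower number. Among the compounds with values here, no compound with butyl has been measured, and methyl is much shorter, so the expectation is loose. The expected change is an 18-fold lower number from compound 2 to compound 3 (1.26 log units; beyond the scatter). For compound 3 the estimated value is 450 nM, with an expected range of 120 nM to 2000 nM.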

Compound 3, half-maximal effective concentration: 1700 nM
Compound 3: middle estimate off by 3.8-fold (0.58 log units), on the low side; the measured number falls inside the stated range.
By their numbers in this assay, from the lowest: compound 1; then compound 3; then compound 2.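

In this assay, butyl in place of acetyl gives a 4.8-fold lower number from compound 2 to compound 3 (0.68 log units; beyond the scatter), so a plain carbon chain at this aromatic carbon recovers part of what the acetyl step lost. The recovery is only partial, however: extending methyl to butyl gives a 6.1-fold higher number from compound 1 to compound 3 (0.78 log units; beyond the scatter), which shows that two plain carbon chains at this place are not interchangeable and puts compound 3 between the other two compounds. Nothing available here explains these differences.

As far as these compounds go, it remains open whether the number climbs steadily as the chain grows from methyl to butyl, and ethyl or propyl on the aromatic carbon would test this. From the compounds shown here alone, it is also open how a methoxy group or an amine at this place would compare with acetyl and butyl.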